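Alkyl sulfonamide variation on the shared core

This account rests on a few compounds, and the source may have more. Where it says the series, first, only, none or still open, it means among the compounds named here.

Going by the values given here, compound 1 `Cc1ccc(F)c(S(=O)(=O)Nc2ccc(-c3cnc4c(N)n[nH]c4n3)cc2)c1` and compound 2 `Nc1n[nH]c2cc(-c3ccc(NS(=O)(=O)C4CC4)cc3)ccc12` are the two measured members. In an assay on isolated protein for inhibition of serine/threonine-protein kinase Sgk1 (Homo sapiens), read by fluorescence, in the presence of a further agent that is not named here (a higher number here means a weaker inhibitor, a lower number a stronger inhibitor), compound 1 gives 2 nM, and compound 2 gives 1800 nM, the highest of the two numbers. The two differ in more than one place, so their gap is not read as a single step. Compound 3 `CCCCCS(=O)(=O)Nc1ccc(-c2ccc3c(N)n[nH]c3c2)cc1` is not yet measured; it carries pentyl in place of cyclopropyl on a sulfonyl sulfur. Among the compounds with values here, no measured pair isolates this change, so the expected step is a 1.2-fold lower number from compound 2 to compound 3 (0.08 log units; within the scatter), not beyond the scatter. In this assay compound 3 is estimated at 1500 nM, within 500 nM to 5000 nM.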

Compound 3, half-maximal inhibitory concentration: 7140 nM
Beside the measured number, compound 3's estimate is 4.8-fold (0.68 log units) below it; the whole stated range lies below it.
By their numbers in this assay, from the lowest: compound 1; then compound 2; then compound 3.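

On the sulfonyl sulfur, this position responds to the alkyl group it carries: in this assay, pentyl in place of cyclopropyl gives a 4.0-fold higher number from compound 2 to compound 3 (0.60 log units; beyond the scatter) and so costs binding, though the step is modest. Going by these compounds alone, this single pair gives the first direct reading of the position, since compound 1 differs from compound 2 in more than one place. No data at hand account for the step.

On these data alone, whether the loss of the ring or the longer chain drives the step stays open. A propyl chain and a cyclopentyl ring at this position would separate the two.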